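One ring swapped on an oxygen: what follows?

The source may hold more compounds than are shown below. What is called first, only, known or untested is meant among the compounds shown, and "the series" means these compounds.

Compound 1 `C[C@@H](Cn1c(=O)[nH]/c(=N\c2ccc(Oc3ccccn3)cc2)n(Cc2ccc(Cl)cc2)c1=O)C(=O)O`: 2.7 mL/min/kg
Compound 2 `C[C@@H](Cn1c(=O)[nH]/c(=N\c2ccc(Oc3ccnc(F)c3)cc2)n(Cc2ccc(Cl)cc2)c1=O)C(=O)O`: 5.9 mL/min/kg

In an ADME assay on the whole organism (Rattus norvegicus) for pharmacokinetics, at a dose of 1 mg/kg by the intravenous route (a higher number here means faster removal of the compound, a lower number slower removal), compound 2 has the higher of the two values, 5.9 mL/min/kg. Compound 3 `C[C@@H](Cn1c(=O)[nH]/c(=N\c2ccc(Oc3ccsn3)cc2)n(Cc2ccc(Cl)cc2)c1=O)C(=O)O` differs from it by 1,2-thiazol-3-yl in place of 2-fluoropyridin-4-yl on an oxygen on an aromatic ring, with 1,2-thiazol-3-yl in place of 2-fluoropyridin-4-yl on an oxygen on an aromatic ring. Among the compounds with values here, one measured step bears on this place: a 2.2-fold higher number from compound 1 to compound 2 (0.34 log units; beyond the scatter), modest but beyond the scatter. Within the data shown here, with only this step as a guide, the direction remains uncertain, but a modest change is expected, leaning lower: a 1.5-fold lower number from compound 2 to compound 3 (0.17 log units; within the scatter). For compound 3 the estimate is 4 mL/min/kg, with an expected range of 1.8 mL/min/kg to 10 mL/min/kg.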

Compound 3, clearance: 2.2 mL/min/kg
Estimate against measurement, compound 3: 1.8-fold (0.26 log units) above, and the stated range covers the measured number.
By their numbers in this assay, from the lowest: compounds 3 and 1 (each within the scatter of the next); then compound 2.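

In this assay, this place on the oxygen on an aromatic ring now holds a five-membered ring as well as six-membered ones: a 2.7-fold lower number from compound 2 to compound 3 (0.43 log units; beyond the scatter), whereas a 1.2-fold lower number from compound 1 to compound 3 (0.09 log units; within the scatter). Thus 1,2-thiazol-3-yl and pyridin-2-yl give numbers that cannot be told apart, and 2-fluoropyridin-4-yl alone stands apart from both. No measurement shown here explains this difference.

As far as these compounds go, the pyridine rings of compound 1 and compound 2 differ in both the fluorine and the point of attachment, and which of these goes with the higher number stays open. From the compounds shown here alone, how a plain pyridin-4-yl or a phenyl would behave at this place also remains open.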